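Halogen change on the aryl ring and microsomal half-life

The compounds below may be only part of what the source reports. "The series", "measured", "known", "first", "only" and "open" are said of these compounds alone.

Measured compounds:
- compound 1 `Clc1ccc(-c2nc(NCCNc3ccccn3)ncc2-c2ncc[nH]2)c(Cl)c1`; in an ADME assay on microsomes from liver (Rattus norvegicus) for metabolic stability (on this read-out higher numbers stand for a longer-lived compound and lower numbers for a shorter-lived compound), compound 1 gives > 0.5 h, a limit of the assay rather than a number.
- compound 2 `Nc1nc(NCCNc2ncc(-c3ncc[nH]3)c(-c3ccccc3Cl)n2)ccc1[N+](=O)[O-]`; in this assay compound 2 gives > 0.5 h, again a limit of the assay.
- compound 3 `Nc1nc(NCCNc2ncc(-c3ncc[nH]3)c(-c3ccc(F)cc3F)n2)ccc1[N+](=O)[O-]`; in this assay compound 3 gives > 0.5 h, also a limit of the assay.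

Compound 2 therefore stands at the limit that every value shown in this assay sits at, as the limit of > 0.5 h in this assay, at which 3 of the 3 values shown sit, shows; the set gives only a lower bound, no spread. Going by the values given here, the one step between measured neighbours, a step that the two limits leave unreadable from compound 2 to compound 3, cannot be read because both ends are limits, so it offers no direction or size to carry over.

Compound 4 `Nc1nc(NCCNc2ncc(-c3ncc[nH]3)c(-c3ccc(F)cc3Br)n2)ccc1[N+](=O)[O-]` differs from compound 2 by 2-bromo-4-fluorophenyl in place of 2-chlorophenyl on an aromatic carbon. Among the compounds with values here, no measured step bears readably on this change. Because the limit of > 0.5 h in this assay, at which 3 of the 3 values shown sit, places all three measured compounds at the same limit, the expectation for compound 4 in this assay is simply that it too clears that limit, with no step beyond the scatter anticipated in either direction. Compound 4 is expected at 1 h, in the range 0.5 h to 3 h, most likely reported again only as a limit. The step expected is a step that the limit leaves unreadable from compound 2 to compound 4.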

Compound 4, half-life: > 0.5 h
Compound 4 gave a limit, no number; the forecaster's own chance of this, stated with the estimate: 80%; the middle value does not contradict the limit.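

In this assay compound 4 gives > 0.5 h, a limit of the assay and not a number. Its steps from compound 2 and from compound 3 cannot be read, as both ends of each are limits. The compounds shown leave open what the half-life of any of them is, and whether these halogen changes alter it.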